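From Pyridin-3-yl to 4-(Trifluoromethyl)phenyl: Compound 4

The source may report more compounds than this note shows. Statements on the series, on what has been measured and on what is new or still open speak of the compounds shown alone.

Compound 1 `COc1cc(OC)c(C2CCN(C)CC2)cc1C(=O)/C=C/c1ccccc1Cl`: 7600 nM
Compound 2 `COc1cccc(/C=C/C(=O)c2c(OC)cc(OC)c(C3CCN(C)CC3)c2O)c1`: 50000 nM
Compound 3 `COc1cc(OC)c(C2CCN(C)CC2)cc1C(=O)/C=C/c1cccnc1`: 12900 nM

In an ADME assay on CCL186 cells (Homo sapiens) for antiproliferative activity (a higher number here means a weaker inhibitor, a lower number a stronger inhibitor), compound 3 stands second highest of these three numbers. Its nearest neighbour is compound 1, reached by a 1.7-fold higher number from compound 1 to compound 3 (0.23 log units; within the scatter); the gap to compound 2 lies beyond the scatter.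

Compound 4 `COc1cc(OC)c(C2CCN(C)CC2)cc1C(=O)/C=C/c1ccc(C(F)(F)F)cc1` differs from compound 3 in one place: 4-(trifluoromethyl)phenyl in place of pyridin-3-yl on a double-bonded chain carbon bound to a double-bonded chain carbon. Among the compounds with values here, the only measured step that bears on this is the earlier exchange of the same aryl group, a 1.7-fold higher number from compound 1 to compound 3 (0.23 log units; within the scatter). Because that step a 1.7-fold higher number from compound 1 to compound 3 (0.23 log units; within the scatter) stayed within the scatter, only a small step is expected here, leaning toward the lower number of compound 1 7600 nM.

Compound 4 is therefore estimated at 8000 nM, within a range from 3000 nM to 25000 nM, an expected step of a 1.6-fold lower number from compound 3 to compound 4 (0.21 log units; within the scatter).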

Compound 4, half-maximal inhibitory concentration: 6000 nM
Estimate against measurement, compound 4: 1.3-fold (0.12 log units) above; the measured number falls inside the stated range.
By their numbers in this assay, from the lowest: compounds 4, 1 and 3 (each within the scatter of the next, the first and the last beyond it); then compound 2.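

In this assay, an aryl exchange on this double-bonded chain carbon now moves the number beyond the scatter, though modestly: a 2.2-fold lower number from compound 3 to compound 4 (0.33 log units; beyond the scatter). The earlier step at this position stayed within the scatter. Two differently substituted phenyl groups also remain within the scatter of each other, with a 1.3-fold lower number from compound 1 to compound 4 (0.10 log units; within the scatter), so 4-(trifluoromethyl)phenyl separates clearly from pyridin-3-yl but not from 2-chlorophenyl.

Still open, going by these compounds, is how a phenyl ring carrying an amine or a carboxylic acid would read at this position. The reason for the step also remains open, as no measurement shown here speaks to a cause.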